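The source may hold more compounds than are shown below. What is called first, only, known or untested is meant among the compounds shown, and "the series" means these compounds.

Measured in a physicochemical assay for permeability, using PAMPA; on this read-out lower numbers stand for lower permeability and higher numbers for higher permeability:
- Compound 1 `Cc1ccccc1-c1nc(CN2CCC(C(=O)NCCCN3CC(C)(C)CC(C)(C)C3)CC2)c(C)o1`: > 1390 10^-6 cm/s
- Compound 2 `Cc1oc(-c2ccccc2Cl)nc1CN1CCC(C(=O)NCCCN2C[C@H](C)C[C@H](C)C2)CC1`: 352 10^-6 cm/s
- Compound 3 `Cc1oc(-c2ccc(F)cc2)nc1CN1CCC(C(=O)NCCCN2C[C@H](C)C[C@H](C)C2)CC1`: "not determined" (no result reported)

Compound 1 stands at > 1390 10^-6 cm/s, and this is a limit of the assay, not a number. Going by the values given here, compound 2, at 352 10^-6 cm/s, gives the only exact number in the set. Compound 3 has no usable result, so it adds nothing to the comparison.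

The next compound to be measured is compound 4 `Cc1ccccc1-c1nc(CN2CCC(C(=O)NCCCN3CCCCC3)CC2)c(C)o1`. Its change from compound 1 is a group of 6 heavy atoms (5 carbon, 1 nitrogen; one six-membered non-aromatic ring with 1 hetero atom) in place of a group of 10 heavy atoms (9 carbon, 1 nitrogen; one six-membered non-aromatic ring with 1 hetero atom), on a saturated chain carbon, three bonds along the chain from an amide-type nitrogen. A piperidin-1-yl group enters on a saturated chain carbon, three bonds along the chain from an amide-type nitrogen.

Among the compounds with values here, no measured pair of compounds differs in only one place, so the size of this step remains a judgement. A fall beyond the usual scatter in this assay is expected, with compound 2 at 352 10^-6 cm/s as the guide to scale. The estimated step is an at least 5.5-fold lower number from compound 1 to compound 4 (0.74 log units; beyond the scatter). For compound 4 the estimated value is 250 10^-6 cm/s, with an expected range of 50 10^-6 cm/s to 1000 10^-6 cm/s.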

Compound 4, apparent permeability: 34.5 10^-6 cm/s
The estimate for compound 4 lay 7.2-fold (0.86 log units) above the measured number; measured number outside the range, below it.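

In this assay, the first pair differing in only one place gives an at least 40-fold lower number from compound 1 to compound 4 (1.60 log units; beyond the scatter). This shows that the group on this saturated chain carbon, three bonds along the chain from an amide-type nitrogen, can move the read-out far beyond the scatter, even though the group of 10 heavy atoms and piperidin-1-yl have the same ring type and the same counts of hydrogen-bond donors and acceptors. The value of compound 1 is a limit and not a number, so the step gives only a minimum size: the limit of > 1390 10^-6 cm/s in this assay, at which 1 of the 4 values shown sits.

The compounds shown leave open how the read-out would respond to a pyrrolidine or morpholine ring at this position. They also leave open whether the piperidin-1-yl group would give a step of similar size with a chlorophenyl group on the core, as in compound 2.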